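The source may hold more compounds than are shown below. What is called first, only, known or untested is meant among the compounds shown, and "the series" means these compounds.

Measured compounds:
compound 1 `O=C1NC(=O)/C(=C\c2ccc(OCC(=O)N3N=C(c4ccccc4)CC3c3ccc(F)cc3F)cc2)S1`: 2200 nM
compound 2 `Cc1ccc(C2CC(c3ccccc3)=NN2C(=O)COc2ccc(/C=C3/SC(=O)NC3=O)cc2)cc1`: 1200 nM
compound 3 `O=C1NC(=O)/C(=C\c2ccc(OCC(=O)N3N=C(c4ccccc4)CC3c3ccc(Cl)c(Cl)c3)cc2)S1`: 700 nM

In an assay on cells for inhibition of histone deacetylase 4 (Homo sapiens), read by fluorescence, with a stated time of 30 min (a higher number here means a weaker inhibitor, a lower number a stronger inhibitor), compound 2 stands second highest of the three numbers. Its nearest neighbour is compound 3 (a 1.7-fold lower number from compound 2 to compound 3 (0.23 log units; within the scatter)), its furthest is compound 1 (a 1.8-fold lower number from compound 1 to compound 2 (0.26 log units; within the scatter)); both gaps lie within the scatter, so no ranking among these three is drawn from them.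

Compound 4 `Cc1ccc(C2CC(c3ccc(F)cc3F)=NN2C(=O)COc2ccc(/C=C3/SC(=O)NC3=O)cc2)cc1` differs from compound 2 by 2,4-difluorophenyl in place of phenyl on a carbon with a double bond to nitrogen. Among the compounds with values here, no measured step touches this position. The three known steps, a 1.8-fold lower number from compound 1 to compound 2 (0.26 log units; within the scatter), a 3.1-fold lower number from compound 1 to compound 3 (0.50 log units; beyond the scatter) and a 1.7-fold lower number from compound 2 to compound 3 (0.23 log units; within the scatter), all exchange the aryl group on the saturated ring carbon, and only one of them reaches beyond the scatter, and that modestly. The aryl on the carbon with a double bond to nitrogen is phenyl in every measured compound, so the series gives no direct guide for this change.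

For compound 4 in this assay the expected step is therefore none beyond the scatter, no change at the digits printed from compound 2 to compound 4 (within the scatter). The estimate for compound 4 is 1200 nM, expected between 500 nM and 3000 nM, the width reflecting the absence of any measured step at this position.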

Compound 4, half-maximal inhibitory concentration: 1500 nM
Estimate against measurement, compound 4: 1.3-fold (0.10 log units) below; the range from low to high includes it.
By their numbers in this assay, from the lowest: compounds 3, 2, 4 and 1 (each within the scatter of the next, the first and the last beyond it).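

In this assay, within the data shown here, the first exchange on the carbon with a double bond to nitrogen gives a 1.3-fold higher number from compound 2 to compound 4 (0.10 log units; within the scatter) and so shows that 2,4-difluorophenyl can stand in place of phenyl here with no readable change, at least with 4-methylphenyl on the saturated ring carbon. This single pair gives the position its only reading so far, and it adds no sensitivity to what the exchanges on the saturated ring carbon had shown. No evidence is available on the reason for this result.

Going by these compounds, whether this position stays as flat with a different kind of substituent, such as a carboxylic acid, an amine or a longer alkyl chain in place of the aryl group, remains open. Also open, on these data alone, is whether 2,4-difluorophenyl reads the same here when 3,4-dichlorophenyl sits on the saturated ring carbon, as in compound 3.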